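The source may hold more compounds than are shown below. What is called first, only, known or untested is meant among the compounds shown, and "the series" means these compounds.

Measured compounds:
- compound 1, `COc1ccc(/C=C/C(=N\O)c2ccc(Cl)cc2)cc1`, gives 5850 nM in a functional assay (Mus musculus, strain Balb/c) for inhibition, read by ELISA, with a stated time of 72 h; a lower number here means a stronger inhibitor, a higher number a weaker inhibitor
- compound 2, `O/N=C(\C=C\c1ccc(Cl)cc1)c1ccc(Br)cc1`, gives 14700 nM
- compound 3, `O/N=C(\C=C\c1ccc(Cl)c(Cl)c1)c1ccc(Br)cc1`, gives only a limit of the assay, not a number: < 5000 nM

Among the numbers given, compound 2 stands highest, the weakest inhibitor of the set; compound 1 sits clearly below it. Compound 4, `COc1ccc(/C=C/C(=N\O)c2ccc(Br)cc2)cc1`, comes from compound 2 by methoxy in place of chloro on an aromatic carbon. For the measured compounds named here, the one measured step, an at least 2.9-fold lower number from compound 2 to compound 3 (0.46 log units; beyond the scatter), adds a chloro and does not bear on swapping chloro for methoxy; no measured pair isolates that change. Compound 1 carries the same methoxy together with a chloro on the other ring and gives a markedly lower number than compound 2. Compound 4 is therefore expected to land near compound 1, with an estimated 7000 nM (range 3000 nM to 17000 nM), an expected step of a 2.1-fold lower number from compound 2 to compound 4 (0.32 log units; beyond the scatter) toward stronger inhibition.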

Compound 4, half-maximal inhibitory concentration: < 5000 nM
Compound 4: a limit, no number; the forecaster's own chance of this, stated with the estimate: 15%; middle value at least 1.4-fold (0.14 log units) from the limit.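

In this assay, methoxy in place of chloro on an aromatic carbon, para to a large group, now has a direct measure and gives stronger inhibition, with an at least 2.9-fold lower number from compound 2 to compound 4 (0.46 log units; beyond the scatter). Bromo in place of chloro, with the methoxy kept, gives an at least 1.1-fold lower number from compound 1 to compound 4 (0.06 log units; that floor lies within the scatter), so no real difference between these two halogens can be claimed. Compound 4 gives only a limit of the assay, not a number: the limit of < 5000 nM in this assay, at which 2 of the 4 values shown sit.

From the compounds shown here alone, how far compound 4 lies past that limit stays open. Also open, going by these compounds, is whether an amine, a carboxylic acid or a longer chain at this place would do as well as methoxy.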